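Terpenoid quinone series: removal of the amino acid side chain

The compounds below may be only part of what the source reports. "The series", "measured", "known", "first", "only" and "open" are said of these compounds alone.

Measured so far:
- compound 1 `CC1=CCC[C@H]2[C@](C)(CC3=CC(=O)C=C(NCCC(=O)O)C3=O)[C@@H](C)CC[C@]12C`: 20200 nM
- compound 2 `CC(C)(C)C1=CC(=O)C=CC1=O`: 41600 nM

In a functional assay on Fem-X cells (Homo sapiens) for cytotoxicity, read by MTT assay, with a stated time of 72 h (a lower number here means a stronger inhibitor, a higher number a weaker inhibitor), compound 1 gives 20200 nM, the lowest of the two numbers recorded. Compound 2, a small quinone without the terpenoid core, gives 41600 nM in this assay, a higher number than compound 1, and the gap between the two lies beyond the usual scatter. For the measured compounds named here, no pair differing in a single place has been measured, so no step size can be read directly from the data.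

Compound 3 `CC1=CCC[C@H]2[C@](C)(CC3=CC(=O)C=CC3=O)[C@@H](C)CC[C@]12C` is not yet measured. It differs from compound 1 as follows:

hydrogen in place of (2-carboxyethyl)amino on a double-bonded ring carbon

The change strips the (2-carboxyethyl)amino group from the quinone ring of compound 1 while the core is kept intact. Going by the values given here, with no measured single-point step to lean on, the expectation for compound 3 rests on the observation that compound 1 sits somewhat stronger than the bare quinone compound 2 in this assay. A modest step toward a lower number, at or near the edge of the scatter, is expected in this assay, a 1.7-fold lower number from compound 1 to compound 3 (0.23 log units; within the scatter). Compound 3 is estimated at 12000 nM, with a range from 3000 nM to 40000 nM.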

Compound 3, half-maximal inhibitory concentration: 40300 nM
For compound 3 the middle estimate is 3.4-fold (0.53 log units) below the measured one; measured number outside the range, above it.
By their numbers in this assay, from the lowest: compounds 1, 3 and 2 (each within the scatter of the next, the first and the last beyond it).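

In this assay, for the compounds shown here, the first pair that differs in one place gives a 2.0-fold higher number from compound 1 to compound 3 (0.30 log units; within the scatter) for hydrogen in place of (2-carboxyethyl)amino on a double-bonded ring carbon. At this position, two ring bonds from the ring atom that bears a large group, compound 1 and compound 3 cannot be told apart on these numbers, even though the group that leaves has 6 heavy atoms and both its hydrogen-bond donors and acceptors go with it; on this core, the (2-carboxyethyl)amino group is therefore not shown to matter for the read-out. No measurement is available that would explain this result for the pair.

Open, going by these compounds, is which part of the side chain, if any, counts at this ring carbon: a methyl ester in place of the carboxylic acid, a plain propylamino group without the carboxylic acid, or a longer chain ending in a carboxylic acid would separate the nitrogen from the acid. Also open, on these data alone, is whether a step of this kind holds on a core other than that of compound 1.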